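Swapping in a 1H-indazol-4-yl group on the shared core

A few compounds are considered here, and "the series" means these few. Any claim that something is new, unique, unknown or untested is made for them only; others in the source may bear on it.

Measured so far in a physicochemical assay for lipophilicity, at pH 7.4 (a higher number here means a more lipophilic compound, a lower number a more polar compound), are two compounds:
- compound 1 `CNC(=O)c1cc(C(=O)NC2CC2)c(C)n(Cc2ccccc2)c1=O` with 2.9 as its value
- compound 2 `CNC(=O)c1cc(C(=O)NC2CC2)cn(Cc2nccc3[nH]ccc23)c1=O` with 1.7 as its value

Of these two numbers, compound 2 holds the lower one, with 1.7 as its reading, and its gap to compound 1 lies beyond the usual scatter. Compound 3 `CNC(=O)c1cc(C(=O)NC2CC2)cn(Cc2cccc3[nH]ncc23)c1=O` has not yet been measured. Its difference from compound 2 is a group of 9 heavy atoms (7 carbon, 2 nitrogen; one five-membered aromatic ring with 2 hetero atoms, one six-membered aromatic ring of carbon only) in place of a group of 9 heavy atoms (7 carbon, 2 nitrogen; one five-membered aromatic ring with 1 hetero atom, one six-membered aromatic ring with 1 hetero atom), on a saturated chain carbon bound to an aromatic nitrogen and the two have the same atoms, joined differently. Going by the values given here, no measured pair differs in one place only, and the data therefore give no direct precedent for this exchange. The expected step of a number 0.60 log units higher from compound 2 to compound 3 (beyond the scatter) is upward and moderate, somewhat beyond the scatter. For compound 3 the estimated value is 2.3 with 1.8 to 2.8 as the expected range.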

Compound 3, distribution coefficient: 1.5
Beside the measured number, compound 3's estimate is 0.80 log units above it, outside the stated range (below it).
By their numbers in this assay, from the lowest: compounds 3 and 2 (each within the scatter of the next); then compound 1.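

On a saturated chain carbon bound to an aromatic nitrogen, placing 1H-indazol-4-yl where the other fused pair of rings stood gives, in this assay, a number 0.20 log units lower from compound 2 to compound 3 (within the scatter). Going by these compounds alone, this is the first pair that differs in one place only, and it gives a direct reading at this position: the same atoms, joined differently, with the same counts of hydrogen-bond donors and acceptors, leave the two compounds within the scatter of each other. Nothing available bears on why the two read alike.

Compound 1 differs from compound 2 and compound 3 in more than one place, so it cannot show what the group on this chain carbon contributes alone. Going by these compounds, how this position would respond to a group of a different composition, such as an amine or a carboxylic acid on the fused rings, remains open.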